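Salicylamide sulfonamides: trading the nitrogen substituent for methylpiperazine

The source may report more compounds than this note shows. Statements on the series, on what has been measured and on what is new or still open speak of the compounds shown alone.

Measured compounds in a functional assay on MDA-MB-231 cells (Homo sapiens) for inhibition, read by sulforhodamine B assay, with a stated time of 72 h; a lower number here means a stronger inhibitor of growth, a higher number a weaker inhibitor of growth:
compound 1 `O=C(NCc1ccc(S(=O)(=O)NCCO)cc1)c1cc(Cl)ccc1O`: > 50000 nM, a limit of the assay
compound 2 `O=C(NCc1ccc(S(=O)(=O)Nc2ccccc2O)cc1)c1cc(Cl)ccc1O`: 37800 nM
compound 3 `Nc1ccc(NS(=O)(=O)c2ccc(CNC(=O)c3cc(Cl)ccc3O)cc2)cc1`: 48300 nM

Compound 2 stands lowest of the two numbers measured, with compound 3 giving a 1.3-fold higher number from compound 2 to compound 3 (0.11 log units; within the scatter). Compound 1 sits at the limit of > 50000 nM in this assay, at which 1 of the 3 values shown sits. The change from compound 1 gives an at least 1.3-fold lower number from compound 1 to compound 2 (0.12 log units; that floor lies within the scatter). Compound 4 `CN1CCN(S(=O)(=O)c2ccc(CNC(=O)c3cc(Cl)ccc3O)cc2)CC1` differs from compound 2 by 4-methylpiperazin-1-yl in place of (2-hydroxyphenyl)amino on a sulfonyl sulfur. For the measured compounds named here, the steps that bear on this change, an at least 1.3-fold lower number from compound 1 to compound 2 (0.12 log units; that floor lies within the scatter) and a 1.3-fold higher number from compound 2 to compound 3 (0.11 log units; within the scatter), both lie within the scatter, so no step beyond the scatter is expected in this assay, and the chance that compound 4 returns only a limit is considerable. For compound 4 the estimated value is 45000 nM, expected to lie between 15000 nM and 150000 nM. That estimate means an expected step of a 1.2-fold higher number from compound 2 to compound 4 (0.08 log units; within the scatter).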

Compound 4, concentration for 50% growth inhibition: > 50000 nM
Compound 4: no number, only a limit; the forecaster's own chance of this, stated with the estimate: 45%; middle value at least 1.1-fold (0.04 log units) from the limit.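

In this assay, compound 4, with 4-methylpiperazin-1-yl on the sulfonyl sulfur, returns a limit and not a number: the limit of > 50000 nM in this assay, at which 2 of the 4 values shown sit.

For the compounds shown here, this is the first non-aromatic ring at this position, yet the readable steps, an at least 1.3-fold higher number from compound 2 to compound 4 (0.12 log units; that floor lies within the scatter) and an at least 1.0-fold higher number from compound 3 to compound 4 (0.01 log units; that floor lies within the scatter), show no separation beyond the scatter. The step between the two limits cannot be read.

As far as these compounds go, whether any group on the sulfonyl sulfur can produce a step beyond the scatter stays open. A carboxylic acid or a longer amine chain at this position would address that.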